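Benzyl Selenium Group Replaces Methylsulfanyl on Shared Core

The source may hold more compounds than are shown below. What is called first, only, known or untested is meant among the compounds shown, and "the series" means these compounds.

Two compounds were measured in a functional assay on PC-3 cells (Homo sapiens) for cytotoxicity, read by MTT assay, with a stated time of 72 h; on this read-out lower numbers stand for stronger inhibition of growth and higher numbers for weaker inhibition of growth. Compound 1 `C[Se]/C(=N\C(=O)c1cc2ccccc2s1)NC(=O)c1cc2ccccc2s1` gives 37200 nM. Compound 2 `CS/C(=N\C(=O)c1csc([N+](=O)[O-])c1)NC(=O)c1csc([N+](=O)[O-])c1` gives 41500 nM, and this number stays within the scatter of compound 1, so the two values cannot be told apart. For the measured compounds named here, no step between measured compounds that differ in a single place is available from these two, since compound 1 and compound 2 differ in more than one place.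

Compound 3 `O=C(/N=C(/NC(=O)c1csc([N+](=O)[O-])c1)[Se]Cc1ccccc1)c1csc([N+](=O)[O-])c1` has not yet been measured. It departs from compound 2 in one place: a group of 8 heavy atoms (7 carbon, 1 selenium; one six-membered aromatic ring of carbon only) in place of a group of 2 heavy atoms (1 carbon, 1 sulfur; no ring), on a carbon with a double bond to nitrogen. The leaving group is the methylsulfanyl and the entering group carries a selenium atom together with one six-membered aromatic ring of carbon only.

Going by the values given here, no measured step anchors such a change here, and the two measured values sit close together, so the expected direction for compound 3 in this assay is uncertain. Compound 3 is expected to give about 30000 nM, a step of a 1.4-fold lower number from compound 2 to compound 3 (0.14 log units; within the scatter) from compound 2, with a range from 10000 nM to 90000 nM.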

Compound 3, concentration for 50% growth inhibition: 35900 nM
Estimate against measurement, compound 3: 1.2-fold (0.08 log units) below; low and high end bracket the measured number.
By their numbers in this assay, from the lowest: compounds 3, 1 and 2 (each within the scatter of the next).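

In this assay, for the compounds shown here, the replacement of methylsulfanyl by the selenium-bearing group with its six-membered aromatic ring, on a carbon with a double bond to nitrogen, gives the first step that can be read between compounds differing in one place: a 1.2-fold lower number from compound 2 to compound 3 (0.06 log units; within the scatter). The read-out therefore cannot distinguish these two compounds, even though the entering group has 8 heavy atoms and a ring, while the leaving group has 2 heavy atoms and no ring. Nothing shown bears on why the two values cannot be told apart.

The compounds shown leave open how a benzylsulfanyl group or a methyl group on selenium would read on the core of compound 2 in this assay, so the selenium atom and the aromatic ring cannot be separated in this step. They also leave open whether an amine or a longer alkyl chain on this carbon would stay within the scatter of compound 2, and whether the same replacement on the core of compound 1 would behave in the same way.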